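Compound 1 and its 3,4-difluorophenyl counterpart

The source may hold more compounds than are shown below. What is called first, only, known or untested is meant among the compounds shown, and "the series" means these compounds.

Going by the values given here, in a functional assay on LNCaP cells (Homo sapiens) for antiproliferative activity (on this read-out lower numbers stand for stronger inhibition and higher numbers for weaker inhibition), compound 1 `CNC(=O)C[C@@H]1C[C@@H](c2ccc(Cl)c(Cl)c2)[C@H](NC(=O)c2cc(-c3c(Cl)cnn3C)c(Cl)o2)CN1` gives 40 nM, the lowest of the three numbers measured so far. Compound 2 `Cn1ncc(Cl)c1-c1cc(C(=O)N[C@@H]2CN[C@H](CCCO)C[C@H]2c2ccc(Cl)c(Cl)c2)oc1Cl` gives 210 nM, and compound 3 `Cn1ncc(Cl)c1-c1cc(C(=O)N[C@@H]2CN[C@H](CC(=O)O)C[C@H]2c2ccc(Cl)c(Cl)c2)oc1Cl` gives 640 nM. These compounds differ only in the chain that replaces or alters the (methylcarbamoyl)methyl group of compound 1. The steps are a 5.3-fold higher number from compound 1 to compound 2 (0.72 log units; beyond the scatter) and a 16-fold higher number from compound 1 to compound 3 (1.20 log units; beyond the scatter), while the remaining one is a 3.0-fold higher number from compound 2 to compound 3 (0.48 log units; beyond the scatter).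

Compound 4 `CNC(=O)C[C@@H]1C[C@@H](c2ccc(F)c(F)c2)[C@H](NC(=O)c2cc(-c3c(Cl)cnn3C)c(Cl)o2)CN1` keeps the (methylcarbamoyl)methyl group and instead places 3,4-difluorophenyl in place of 3,4-dichlorophenyl on a saturated ring carbon. Among the compounds with values here, all three measured compounds carry 3,4-dichlorophenyl, so no measured step tests this swap directly. The measured steps offer only indirect guidance: they show that the numbers in this small set can shift well beyond the scatter after one change. Compound 1 also sits at the low end, and a 5.3-fold higher number from compound 1 to compound 2 (0.72 log units; beyond the scatter) is the smallest move away from it. A modest step towards a higher number in this assay is therefore expected, though with wide uncertainty. The expected change is a 3.0-fold higher number from compound 1 to compound 4 (0.48 log units; beyond the scatter). Compound 4 is estimated at 120 nM, with an expected range of 40 nM to 400 nM.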

Compound 4, half-maximal inhibitory concentration: 50 nM
For compound 4 the middle estimate is 2.4-fold (0.38 log units) above the measured one, and the stated range covers the measured number.
By their numbers in this assay, from the lowest: compounds 1 and 4 (each within the scatter of the next); then compound 2; then compound 3.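

In this assay, putting 3,4-difluorophenyl in place of 3,4-dichlorophenyl on the saturated ring carbon gives a 1.3-fold higher number from compound 1 to compound 4 (0.10 log units; within the scatter) and so leaves the two compounds indistinguishable on this read-out. Going by these compounds alone, this is the first view of this position, as the earlier compounds all carry 3,4-dichlorophenyl and differ only in their chain, where a 5.3-fold higher number from compound 1 to compound 2 (0.72 log units; beyond the scatter) and a 16-fold higher number from compound 1 to compound 3 (1.20 log units; beyond the scatter) both lie beyond the scatter; here, one pair of ring halogens can replace the other, with the heavy-atom count unchanged, without a change that can be told from that scatter. Nothing measured here explains why these two compounds read alike.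

A plain phenyl ring or a bulkier 3,4-dimethoxyphenyl group at this position could still behave quite differently, so this single pair does not show how much variation the position accepts. As far as these compounds go, it is also open whether the same swap would leave the number as little changed on the carboxylic acid chain of compound 3 or the hydroxyl-bearing chain of compound 2.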